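The source may report more compounds than this note shows. Statements on the series, on what has been measured and on what is new or still open speak of the compounds shown alone.

Going by the values given here, in a functional assay (cardiac atrium) for agonist activity, with Cavia porcellus as the target (a lower number here means that less compound is needed, a higher number that more compound is needed for the effect), compound 1 `CC1=NC(C)=C([N+](=O)[O-])C(c2ccccn2)/C1=C(\O)OC(C)(C)C` gives 1810000 nM, its only single number, with one further entry lacking one. Compound 3 `COCCO/C(O)=C1\C(C)=NC(C)=C([N+](=O)[O-])C1c1ccccn1` carries 2-methoxyethyl in place of tert-butyl on an oxygen on an unsaturated carbon. Among the compounds with values here, no measured step isolates a single change. Within the data shown here, the only guide to size is compound 2 `CC1=NC(C)=C([N+](=O)[O-])C(c2ccccn2)/C1=C(\O)OC1CCCCC1`, whose 3700 nM; 8450 nM (2 entries) lies far lower than the value of compound 1. A sizeable fall in the concentration needed in this assay is therefore expected, estimated as a 60-fold lower number from compound 1 to compound 3 (1.78 log units; beyond the scatter). For compound 3 the estimated value is 30000 nM, with an expected range of 3000 nM to 300000 nM.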

Compound 3, half-maximal effective concentration: 9700 nM
Compound 3: middle estimate off by 3.1-fold (0.49 log units), on the high side; the range from low to high includes it.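

With the heavy-atom count unchanged, 2-methoxyethyl in place of tert-butyl on this oxygen gives a 190-fold lower number from compound 1 to compound 3 (2.27 log units; beyond the scatter) in this assay, so that count alone does not set the value at this position. A group without a ring also reaches the low range here: compound 3, at 9700 nM, stands close to the repeat entries of compound 2, the only guide to spread in this series: the several entries of compound 2 in this assay, 3700 nM; 8450 nM (2 entries)

Going by these compounds alone, the single step changes branching and adds the ether oxygen together, so the two cannot be separated. A plain butyl chain on the same oxygen would separate them.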